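Chain extension on the aryl biguanide series

The compounds below may be only part of what the source reports. "The series", "measured", "known", "first", "only" and "open" are said of these compounds alone.

Compound 2 `CCCCNC(=N)NC(=N)Nc1ccc(Cl)cc1` is a four-carbon-chain aryl biguanide, and compound 1 `CCCCS(=O)(=O)c1ccc(NC(=N)NC(=N)NCCCCCCNC(=N)NC(=N)Nc2ccc(S(=O)(=O)CCCC)cc2)cc1` a bis-biguanide joined through a six-carbon linker. In a physicochemical assay for lipophilicity, in phosphate buffer, measured as octanol-water partition, at pH 11.5 (a higher number here means a more lipophilic compound, a lower number a more polar compound), compound 2 gives 3.13, and compound 1 gives 3.1; the two numbers sit within the scatter of each other, so neither can be set apart from the other on this assay.

Compound 3 `CCCCCCCCCCNC(=N)NC(=N)Nc1ccc(Cl)cc1` has not been measured. Its difference from compound 2 is hexyl in place of hydrogen on a saturated chain carbon, four bonds along the chain from an amine nitrogen. With six more chain carbons and no added donor, acceptor or ring, the step is expected to be large and upward: a number 2.47 log units higher from compound 2 to compound 3 (beyond the scatter) is the estimated step from compound 2 to compound 3, well beyond the scatter. Within the data shown here, compound 3 is therefore estimated at 5.6, within a range of 4.6 to 6.6, the width reflecting that no step of this kind has yet been measured.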

Compound 3, partition coefficient: 6.13
The estimate for compound 3 lay 0.53 log units below the measured number, and the stated range covers the measured number.
By their numbers in this assay, from the lowest: compounds 1 and 2 (each within the scatter of the next); then compound 3.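

Hexyl in place of hydrogen on a saturated chain carbon, four bonds along the chain from an amine nitrogen, gives the first step in the series that differs in one place: in this assay, the step is a number 3.00 log units higher from compound 2 to compound 3 (beyond the scatter). This position therefore responds strongly to this added chain, which compounds 1 and 2 could not show. No measurement shown accounts for the size of this step.

Open, going by these compounds, is how the number runs at chain lengths between those of compound 2 and compound 3, and whether a longer chain continues the rise. Also open, on these data alone, is whether a hydroxyl or a carboxylic acid at the chain end, or a cyclohexyl group in place of hexyl, would retain the step.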